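From Thiophen-2-yl to 4-Methylphenyl on a Carbonyl Carbon

The source may report more compounds than this note shows. Statements on the series, on what has been measured and on what is new or still open speak of the compounds shown alone.

In a functional assay on HepG2 cells (Homo sapiens) for inhibition, read by MTT assay, with a stated time of 48 h (a lower number here means a stronger inhibitor, a higher number a weaker inhibitor), compound 1 (`N#Cc1c(-c2ccccc2)nc2c(c(-c3ccccc3)nn2-c2ccccc2)c1-c1ccc(N2CCCCC2)cc1`) gives 30900 nM. Compound 2 (`O=C(C=CNc1cc(-c2ccccc2)nn1-c1ccccc1)c1cccs1`) gives 2420 nM, the lower of the two numbers, and its gap to compound 1 lies beyond the usual scatter. Compound 3 (`Cc1ccc(C(=O)C=CNc2cc(-c3ccccc3)nn2-c2ccccc2)cc1`) differs from compound 2 in one place, with 4-methylphenyl in place of thiophen-2-yl on a carbonyl carbon. For the measured compounds named here, no measured pair differs in a single place, so the data give no direct guide to the size of this step. As one aromatic ring is exchanged for another, the expectation stays close to compound 2 at 2420 nM. The step expected in this assay is none beyond the scatter, an estimated 1.2-fold higher number from compound 2 to compound 3 (0.09 log units; within the scatter). Compound 3 is expected at 3000 nM, with an estimated range of 1000 nM to 12000 nM.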

Compound 3, half-maximal inhibitory concentration: 7320 nM
Compound 3: the middle estimate sits 2.4-fold (0.39 log units) below what was measured, and the stated range covers the measured number.
By their numbers in this assay, from the lowest: compound 2; then compound 3; then compound 1.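

In this assay, for the compounds shown here, the exchange of thiophen-2-yl for 4-methylphenyl on a carbonyl carbon gives the only single-place step available here, a 3.0-fold higher number from compound 2 to compound 3 (0.48 log units; beyond the scatter), which shows that the read-out at this position responds to which aromatic ring is attached. The step is modest but lies beyond the scatter, and within this pair the thiophen-2-yl compound, compound 2, holds the lower number. No measurement at hand bears on the reason for this step. A single step cannot separate the change from a five-membered to a six-membered ring, the loss of the sulfur and the arrival of the methyl. The compounds shown leave open how unsubstituted phenyl, furan-2-yl, or a phenyl ring carrying an amine or a carboxylic acid would read on this carbonyl carbon.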